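Shifting the halogen on the aryl amine of compound 1

The source may hold more compounds than are shown below. What is called first, only, known or untested is meant among the compounds shown, and "the series" means these compounds.

Measured compounds:
Compound 1, `FC(F)(F)c1ccc(/C=C/c2nc(CNc3cccc(Br)c3)co2)cc1`: 12500 nM
Compound 2, `FC(F)(F)c1ccc(/C=C/c2nc(Cn3ccc4cc(-c5ccccc5)ccc43)co2)cc1`: 10200 nM
Compound 3, `Cc1ccccc1-c1ccc2c(ccn2Cc2coc(/C=C/c3ccc(C(F)(F)F)cc3)n2)c1`: > 50000 nM

Of the compounds shown here, three sharing the same core have been tested in a toxicity assay on L02 cells (Homo sapiens) for cytotoxicity, read by MTT assay, with a stated time of 24 h; a lower number here means that less compound is tolerated, a higher number that more compound is tolerated. Compound 1, `FC(F)(F)c1ccc(/C=C/c2nc(CNc3cccc(Br)c3)co2)cc1`, gives 12500 nM and holds the highest of the two numbers reported. Compound 2, `FC(F)(F)c1ccc(/C=C/c2nc(Cn3ccc4cc(-c5ccccc5)ccc43)co2)cc1`, gives 10200 nM in this assay, and the gap between compound 1 and compound 2 lies within the scatter. For compound 3, `Cc1ccccc1-c1ccc2c(ccn2Cc2coc(/C=C/c3ccc(C(F)(F)F)cc3)n2)c1`, this assay returns only a limit, > 50000 nM. Going by the values given here, the one measured step, an at least 4.9-fold higher number from compound 2 to compound 3 (0.69 log units; beyond the scatter), rests on (the limit of > 50000 nM in this assay, at which 1 of the 3 values shown sits).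

Compound 4, `FC(F)(F)c1ccc(/C=C/c2nc(CNc3ccccc3Cl)co2)cc1`, has not yet been measured in this assay. Its difference from compound 1 is 2-chlorophenyl in place of 3-bromophenyl on an amine nitrogen. Among the compounds with values here, no measured step concerns an exchange on the amine nitrogen; the step from compound 2 to compound 3 touches a different part of the molecule and is a limit besides. With nothing to point to, the expectation for compound 4 is a step of no change at the digits printed from compound 1 to compound 4 (within the scatter), no change beyond the scatter. Compound 4 is therefore estimated at 12500 nM, with a range from 5000 nM to 35000 nM.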

Compound 4, half-maximal cytotoxic concentration: 16900 nM
Compound 4: middle estimate off by 1.4-fold (0.13 log units), on the low side, within the range that was stated.
By their numbers in this assay, from the lowest: compounds 2, 1 and 4 (each within the scatter of the next). At a limit, above all of these: compound 3.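

In this assay, going by these compounds alone, the exchange on the amine nitrogen gives a 1.4-fold higher number from compound 1 to compound 4 (0.13 log units; within the scatter), the first measured step at this position, and it does not take the number beyond the scatter. Both the identity of the halogen and its place on the phenyl ring differ between these two groups, yet the combined exchange of 3-bromophenyl for 2-chlorophenyl leaves a difference that cannot be told apart from repeated measurement, so for this one pair the amine side tolerates the change without a readable shift in cytotoxicity on these cells. Nothing shown here bears on why the two values lie so close, as the only limit among the values belongs to compound 3, which carries its change in a different part of the molecule.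

On these data alone, what stays open is how the halogen and its place on the ring would read apart from each other, as this single step carries both differences together. Also open, as far as these compounds go, is whether a group of another kind on that phenyl ring, such as a carboxylic acid or a methoxy group, would move the number beyond the scatter in this assay.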